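The source may report more compounds than this note shows. Statements on the series, on what has been measured and on what is new or still open speak of the compounds shown alone.

Compound 1 `Clc1ccc(Oc2cncc(C3=CC4CNCC(C3)C4)c2)cc1` was measured in an in vitro assay on SH-EP1 cells for displacement of a labelled ligand from Neuronal acetylcholine receptor; alpha4/beta2 (Homo sapiens) (on this read-out lower numbers stand for stronger inhibition and higher numbers for weaker inhibition), where compound 1 gives 1.9 nM. A second measured compound, compound 2 `CN1C[C@@H]2C=C(c3cccnc3)C[C@@H](C2)C1`, gives 9.4 nM in this assay, so compound 1 shows the lower of the two numbers, and the gap between them is beyond the usual scatter of this assay. Within the data shown here, no pair of measured compounds differing in only one place is available, so no measured single step can be quoted.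

Compound 3 `COc1cncc(C2=CC3CNCC(C2)C3)c1` has not yet been measured in this assay. It differs from compound 1 in one place: methyl in place of 4-chlorophenyl on an oxygen on an aromatic ring. Much is removed and little put in its place, so a moderate weakening is expected rather than none, with compound 3 most likely remaining close to compound 1 and compound 2. The step from compound 1 to compound 3 is estimated to be a 1.8-fold higher number from compound 1 to compound 3 (0.27 log units; within the scatter). For compound 3 the estimated value in this assay is 3.5 nM, with a likely range from 1.2 nM to 12 nM.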

Compound 3, inhibition constant: 0.3 nM
Estimate against measurement, compound 3: 12-fold (1.07 log units) above; the whole stated range lies above it.
By their numbers in this assay, from the lowest: compound 3; then compound 1; then compound 2.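

At this position, on an oxygen on an aromatic ring, the 4-chlorophenyl group is not required for a low number in this assay, and methyl in its place gives a 6.3-fold lower number from compound 1 to compound 3 (0.80 log units; beyond the scatter) on the same core. Removing a whole aromatic ring therefore did not weaken the result here; in this one pair, the smaller group goes with the stronger inhibition. No measurement shown here explains why the smaller group gives the lower number.

This single step swaps the ring and its chlorine together, so it leaves open whether either part alone accounts for the gap, and a plain phenyl on this oxygen would separate the two. It also leaves open how the number would move with an ethyl or a longer chain, or with a bare hydroxyl at this place.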